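The compounds below may be only part of what the source reports. "The series", "measured", "known", "first", "only" and "open" are said of these compounds alone.

Measured so far:
compound 1, `N=C(NCCCc1c[nH]cn1)NCCCC(c1ccc(F)cc1)c1ccccn1` — 0.9
compound 2, `N=C(NCCCc1c[nH]cn1)NCCC(c1ccc(Br)cc1)c1ccccn1` — 1

Among the compounds with values here, both compounds share one core and differ only in the aryl group and the chain length on the carbon bearing the two rings; no single-point step between them is counted here. In a functional assay on cardiac atrium for agonist activity at histamine H2 receptor (Cavia porcellus) (on this read-out higher numbers stand for larger maximal responses and lower numbers for smaller maximal responses), compound 2 gives 1, the top of the two numbers, while compound 1 gives 0.9. The gap between them falls within the usual scatter of this assay, so the two values are not distinguished and both represent essentially the full response of the reference agonist.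

Compound 3, `N=C(NCCCc1c[nH]cn1)NCCC(c1ccccn1)c1ccccn1`, is not yet measured. It differs from compound 2 by pyridin-2-yl in place of 4-bromophenyl on a saturated chain carbon bound to an aromatic carbon and a saturated chain carbon. Nothing in the two measured values indicates that the aryl group at this position alters the maximal response, since compound 1 and compound 2 carry different para-substituted phenyl groups yet sit together near the full response. Compound 3 is therefore expected to remain a full or near-full agonist in this assay, estimated at 0.9 with a range from 0.7 to 1. For compound 3 the expected step a number 0.10 lower from compound 2 to compound 3 (within the scatter) is none beyond the scatter.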

Compound 3, intrinsic activity: the largest response reached, as a fraction of the reference agonist's: 1
Beside the measured number, compound 3's estimate is 0.10 below it; the range from low to high includes it.
By their numbers in this assay, from the lowest: compounds 1, 2 and 3 (each within the scatter of the next).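

In this assay there is no change at the digits printed from compound 2 to compound 3 (within the scatter) when pyridin-2-yl takes the place of 4-bromophenyl on a saturated chain carbon bound to an aromatic carbon and a saturated chain carbon. Within the data shown here, this is the first comparison that differs in one place only, and it shows that a ring with a hetero atom and a hydrogen-bond acceptor can stand here in place of a carbon-only ring with a bromine, without the maximal response moving outside the scatter. Nothing at hand explains why the response holds across this change.

Still open, from the compounds shown here alone, is whether a group of another kind on this carbon, such as a cyclohexyl ring, an amine or a carboxylic acid, would keep the maximal response, and what a longer chain does when the aryl groups are held the same. The read-out also gives only the largest response reached, so the concentrations needed to reach it, and any effect of this change on them, remain undefined for this series.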